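Trifluoromethyl in place of hydroxy on a saturated ring carbon

The source may hold more compounds than are shown below. What is called first, only, known or untested is meant among the compounds shown, and "the series" means these compounds.

Compound 1 `COC(=O)C1=C(CN2CCNCC2)NC(c2nccs2)=NC1(C)c1ccc(F)cc1`: 39 mL/min/kg
Compound 2 `COC(=O)C1=C(CN2CCC(O)C2)NC(c2nccs2)=NC1(C)c1ccc(F)cc1`: 83 mL/min/kg

Within the data shown here, in an ADME assay on microsomes from liver (Mus musculus) for metabolic stability, read by LC-MS, using NADPH, with stated times of 10 min and 30 min, tested at 1 uM (a lower number here means slower removal, a higher number faster removal of the compound), compound 2 holds the higher of the two numbers, and compound 1 is its only comparison. Among the measured compounds shown here, the one measured step, a 2.1-fold higher number from compound 1 to compound 2 (0.33 log units; beyond the scatter), comes with 3-hydroxypyrrolidin-1-yl in place of piperazin-1-yl. Compound 3 `COC(=O)C1=C(CN2CCC(C(F)(F)F)C2)NC(c2nccs2)=NC1(C)c1ccc(F)cc1` has not yet been measured and differs from compound 2 by trifluoromethyl in place of hydroxy on a saturated ring carbon. The measured step alters the same part of the molecule but does not replace the hydroxy group, so it bears on this change only loosely. For the measured compounds named here, no measured step shows this exact swap. The expectation therefore starts from compound 2 at 83 mL/min/kg, with a modest rise in this assay expected at most, possibly none beyond the scatter. The expected change is a 1.1-fold higher number from compound 2 to compound 3 (0.06 log units; within the scatter). Compound 3 is estimated at 95 mL/min/kg, with an expected range of 50 mL/min/kg to 175 mL/min/kg.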

Compound 3, clearance in the Mus musculus assay: 88 mL/min/kg
Compound 3: middle estimate off by 1.1-fold (0.03 log units), on the high side; low and high end bracket the measured number.
By their numbers in the Mus musculus assay, from the lowest: compound 1; then compounds 2 and 3 (each within the scatter of the next).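

In the Mus musculus assay, trifluoromethyl in place of hydroxy on this saturated ring carbon does not separate the two compounds, with a 1.1-fold higher number from compound 2 to compound 3 (0.03 log units; within the scatter), while the 3-(trifluoromethyl)pyrrolidin-1-yl group stays apart from piperazin-1-yl, with a 2.3-fold higher number from compound 1 to compound 3 (0.35 log units; beyond the scatter). The same change does separate compound 2 and compound 3 in a physicochemical assay for solubility, read by HPLC, in phosphate buffer, at pH 6.5; on this read-out lower numbers stand for lower solubility and higher numbers for higher solubility: the measured solubility of compound 2, 503 ug/mL, and of compound 3, 13 ug/mL, a 39-fold lower number (1.59 log units; beyond the scatter). In the physicochemical assay compound 2 gives 503 ug/mL and compound 3 gives 13 ug/mL. At this position, then, the swap leaves the clearance number of compound 2 within the scatter while the solubility number falls sharply.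

Going by these compounds, whether a methoxy or an amino group on this ring carbon would keep the higher number of compound 2 in the physicochemical assay stays open. So does whether any such group could bring the number in the Mus musculus assay down towards that of compound 1.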